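From Propyl to Phenyl: One Change, One Expectation

This account rests on a few compounds, and the source may have more. Where it says the series, first, only, none or still open, it means among the compounds named here.

Compound 1, `CCOC(=O)C1=C(C(F)(F)F)NC(=O)NC1c1ccco1`: 15%
Compound 2, `CCCC1=C(C(=O)OCC)C(c2ccco2)NC(=O)N1`: 50%

Of the compounds shown here, two have been measured in an assay on CHO cells for displacement of a labelled ligand from adenosine receptor A1 (Homo sapiens), with a stated time of 60 min, tested at 10 uM; on this read-out lower numbers stand for less inhibition and higher numbers for more inhibition at the one concentration tested (going by the name of the read-out). Compound 1 `CCOC(=O)C1=C(C(F)(F)F)NC(=O)NC1c1ccco1` gives 15%. Compound 2 `CCCC1=C(C(=O)OCC)C(c2ccco2)NC(=O)N1` gives 50% and stands highest of the two numbers, its nearest neighbour being compound 1. Within the data shown here, the only measured step, a number 35 percentage points higher from compound 1 to compound 2 (beyond the scatter), came from a change at the same ring position that is changed next.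

Compound 3 `CCOC(=O)C1=C(c2ccccc2)NC(=O)NC1c1ccco1` is not yet measured. It differs from compound 2 in one place: phenyl in place of propyl on a double-bonded ring carbon. The step from compound 1 to compound 2 shows that a group at this position can move the read-out by a large amount, but it involves trifluoromethyl and propyl, not phenyl, so it gives no direction for the present change. Among the measured compounds shown here, no other step bears on it.

For compound 3 the expected step of a number 10 percentage points lower from compound 2 to compound 3 (within the scatter) is small, with no clear direction beyond the scatter, and a wide range must be allowed. Compound 3 is therefore estimated to give 40%, between 10% and 70%.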

Compound 3, a percentage reported as inhibition, at one concentration (the size of the read-out at that concentration, not a potency): 3%
Estimate against measurement, compound 3: 37 percentage points above; the measured number lies below the stated range.
By their numbers in this assay, from the lowest: compound 3; then compound 1; then compound 2.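

In this assay, phenyl on the double-bonded ring carbon gives a number 47 percentage points lower from compound 2 to compound 3 (beyond the scatter), so this position responds strongly to a swap between two groups that both carry only carbon, with no hydrogen-bond donors or acceptors and no net charge in either. Phenyl also falls short of trifluoromethyl, with a number 12 percentage points lower from compound 1 to compound 3 (beyond the scatter), which places propyl clearly above both other groups in these three compounds and shows that a carbon-only group at this position does not by itself keep the number high. The step from propyl to phenyl adds carbon atoms and a six-membered aromatic ring, but nothing available here explains why the number falls.

As far as these compounds go, whether the high number belongs to open chains in general remains open, since a shorter or longer chain such as ethyl or butyl could hold it, raise it or lose it. It is equally unsettled whether a saturated ring such as cyclohexyl would follow propyl or phenyl, and whether an amine at this position would give a higher number than either.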